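Swapping a nitrile for a methoxyphenyl on a fatty acid receptor agonist

The source may report more compounds than this note shows. Statements on the series, on what has been measured and on what is new or still open speak of the compounds shown alone.

Of the compounds shown here, two have been measured in a functional assay on 1321-N1 cells for agonist activity at Free fatty acid receptor 1 (Homo sapiens), read by calcium flux; on this read-out lower numbers stand for an effect already at smaller amounts and higher numbers for an effect only at larger amounts of compound. Compound 1 `O=C(O)CCc1ccc2oc(-c3ccccc3)cc2c1` gives 2450 nM. Compound 2 `N#Cc1cccc(COc2ccc(CCC(=O)O)cc2)c1` gives 525 nM, the lower of the two numbers and well beyond the usual scatter from compound 1. Among the compounds with values here, no pair of measured compounds differs in only one place, so no single structural change has yet been tied to a change in the read-out.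

Compound 3 `COc1ccccc1-c1cccc(COc2ccc(CCC(=O)O)cc2)c1` is not yet measured. It differs from compound 2 in one place: 2-methoxyphenyl in place of cyano on an aromatic carbon. Without a measured step of this kind, the expectation for compound 3 rests on compound 2 alone and on the nature of the change. The change from compound 2 to compound 3 is expected to shift this assay by a 4.4-fold lower number from compound 2 to compound 3 (0.64 log units; beyond the scatter), towards a smaller number. For compound 3 the expected value in this assay is 120 nM, with a likely range from 30 nM to 450 nM.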

Compound 3, half-maximal effective concentration: 120 nM
Compound 3: middle estimate and measured number agree at the digits printed; measured number inside the range.
By their numbers in this assay, from the lowest: compound 3; then compound 2; then compound 1.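

Within the data shown here, replacing cyano with 2-methoxyphenyl in this assay gives a 4.4-fold lower number from compound 2 to compound 3 (0.64 log units; beyond the scatter) and is the first single change here that can be tied to a shift in the read-out. It shows that this position, on an aromatic carbon and meta to a large group, can take a group of 8 heavy atoms with its own aromatic ring in place of one of 2 heavy atoms with no ring, and that the number still falls. Nothing shown here identifies the cause of this shift.

It remains open whether the added ring or the methoxy group on it accounts for the step, as the compounds shown include no plain phenyl at this position. On these data alone, how a pyridine ring or an amine would read at the same place also remains unknown.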